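A few compounds are considered here, and "the series" means these few. Any claim that something is new, unique, unknown or untested is made for them only; others in the source may bear on it.

In an in vitro ADME assay on microsomes from liver (Homo sapiens) for metabolic stability (a higher number here means faster removal of the compound, a lower number slower removal), compound 1 `O=C(COCc1cscn1)N1CCN(c2ccc(Cl)cc2Cl)CC1` gives 62 mL.min-1.g-1 and compound 2 `O=C(COCc1nccs1)N1CCN(c2ccc(Cl)cc2Cl)CC1` gives 80 mL.min-1.g-1 which places the two level, within the usual scatter. Compound 3 `O=C(COCc1cccs1)N1CCN(c2ccc(Cl)cc2Cl)CC1` carries thiophen-2-yl in place of the 1,3-thiazol-2-yl of compound 2 (thiophen-2-yl in place of 1,3-thiazol-2-yl on a saturated chain carbon bound to an oxygen on a saturated carbon) on a saturated chain carbon bound to an oxygen on a saturated carbon. For the measured compounds named here, the one measured step (a 1.3-fold higher number from compound 1 to compound 2 (0.11 log units; within the scatter)) exchanged 1,3-thiazol-4-yl for 1,3-thiazol-2-yl and stayed within the scatter, so it offers only weak guidance on thiophen-2-yl. From the compounds shown here alone, no step beyond the scatter is expected in this assay (estimated a 1.2-fold higher number from compound 2 to compound 3 (0.07 log units; within the scatter)) and the direction remains open. For compound 3 the estimate is 95 mL.min-1.g-1 (expected range 50 mL.min-1.g-1 to 180 mL.min-1.g-1).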

Compound 3, intrinsic clearance in microsomes: 360 mL.min-1.g-1
Beside the measured number, compound 3's estimate is 3.8-fold (0.58 log units) below it; the whole stated range lies below it.
By their numbers in this assay, from the lowest: compounds 1 and 2 (each within the scatter of the next); then compound 3.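

In this assay, the ring on this saturated chain carbon matters more than the two thiazole compounds suggested: thiophen-2-yl gives a 4.5-fold higher number from compound 2 to compound 3 (0.65 log units; beyond the scatter) and a 5.8-fold higher number from compound 1 to compound 3 (0.76 log units; beyond the scatter). Both thiazolyl groups carry a ring nitrogen and thiophen-2-yl has none, and among these three compounds only the ring without nitrogen stands apart. Nothing available explains this difference. Still open, from the compounds shown here alone, is whether a phenyl or pyridin-2-yl ring at this place would be removed as quickly as compound 3 or stay level with the thiazole compounds.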